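Naphthyl for pyridyl on the hydrazone carbon of compound 1

This account rests on a few compounds, and the source may have more. Where it says the series, first, only, none or still open, it means among the compounds named here.

Measured compounds:
compound 1 `CCCSc1nc(N/N=C/c2cccnc2)c2nnn(Cc3ccccc3)c2n1`: 38100 nM
compound 2 `CCCSc1nc(N/N=C(\C)c2ccccc2O)c2nnn(Cc3ccccc3Cl)c2n1`: 35000 nM
compound 3 `CCCSc1nc(N/N=C(\C)c2ccccc2O)c2nnn(Cc3ccc(Br)cc3)c2n1`: 11300 nM

In a functional assay on MGC-803 cells (Homo sapiens) for antiproliferative activity, read by MTT assay, with a stated time of 72 h (a higher number here means a weaker inhibitor, a lower number a stronger inhibitor), compound 1 gives the highest of the three numbers; compound 2 sits within the scatter of it, and compound 3 lies beyond the scatter below it. Going by the values given here, the only step between measured compounds is a 3.1-fold lower number from compound 2 to compound 3 (0.49 log units; beyond the scatter), a change on the saturated chain carbon bound to an aromatic nitrogen, not on the hydrazone carbon.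

Compound 4 `CCCSc1nc(N/N=C/c2ccc3ccccc3c2)c2nnn(Cc3ccccc3)c2n1` differs from compound 1 by naphthalen-2-yl in place of pyridin-3-yl on a carbon with a double bond to nitrogen. Among the compounds with values here, no measured pair changes the group on that carbon, so nothing speaks directly to this step; the size of the one measured step gives only a sense of scale for a single aromatic swap. A modest step is expected, direction uncertain, leaning toward a lower number, so that the expected change is a 1.9-fold lower number from compound 1 to compound 4 (0.28 log units; within the scatter). Compound 4 is estimated at 20000 nM, within 7000 nM to 60000 nM.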

Compound 4, half-maximal inhibitory concentration: > 64000 nM
Compound 4 ended at the assay's limit; the forecaster's own chance of this, stated with the estimate: 10%; middle value at least 3.2-fold (0.50 log units) away from the limit.
By their numbers in this assay, from the lowest: compound 3; then compounds 2 and 1 (each within the scatter of the next). At a limit, above all of these: compound 4.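

In this assay compound 4 gives > 64000 nM, which is a limit of the assay and not a number. Going by these compounds alone, the first measured change on this carbon, naphthalen-2-yl in place of pyridin-3-yl, gives an at least 1.6-fold higher number from compound 1 to compound 4 (0.22 log units; that floor lies within the scatter), so the larger group brings no lower number here, a finding the earlier compounds could not provide. Whether the true gap exceeds the scatter cannot be told, as the step is only a floor set by the ceiling of the assay: the limit of > 64000 nM in this assay, at which 1 of the 4 values shown sits.

Still open, going by these compounds, is whether the ring count or the ring nitrogen of pyridin-3-yl sets this outcome; a phenyl group on this carbon would separate the two. Also open, on these data alone, is whether 4-bromophenyl, as carried by compound 3, would lower the number of compound 1.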